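Changing the Group on the Carbonyl Carbon

The compounds below may be only part of what the source reports. "The series", "measured", "known", "first", "only" and "open" are said of these compounds alone.

Three compounds share one core and differ only in the group attached to the carbonyl carbon. Compound 1 `O=C(Nc1ccc(S(=O)(=O)Nc2ccccc2)cc1)c1ccc(Cl)cc1Br` gives 1020 nM in a functional assay on HEK293 cells for agonist activity at probable G-protein coupled receptor 27 (Homo sapiens), read by a luciferase reporter and beta-arrestin recruitment, with a stated time of 10 min; on this read-out lower numbers stand for an effect already at smaller amounts and higher numbers for an effect only at larger amounts of compound. Compound 2 `Cc1cc(Cl)ccc1C(=O)Nc1ccc(S(=O)(=O)Nc2ccccc2)cc1` gives 912 nM, and compound 3 `Cc1cc(Br)ccc1C(=O)Nc1ccc(S(=O)(=O)Nc2ccccc2)cc1` gives 851 nM, the lowest of the three numbers shown, although a 1.2-fold lower number from compound 1 to compound 3 (0.08 log units; within the scatter) and a 1.1-fold lower number from compound 2 to compound 3 (0.03 log units; within the scatter) both lie within the scatter. Compound 4 `O=C(Nc1ccc(S(=O)(=O)Nc2ccccc2)cc1)c1cc(F)c(Cl)cc1F` carries the change (4-chloro-2,5-difluorophenyl in place of 4-bromo-2-methylphenyl on a carbonyl carbon). The step that bears on it most is the exchange of the whole group at the same place, a 1.2-fold lower number from compound 1 to compound 3 (0.08 log units; within the scatter), and the smaller swaps a 1.1-fold lower number from compound 1 to compound 2 (0.05 log units; within the scatter) and a 1.1-fold lower number from compound 2 to compound 3 (0.03 log units; within the scatter) were equally flat. Compound 4 is therefore expected to move little, a 1.1-fold higher number from compound 3 to compound 4 (0.02 log units; within the scatter), with an estimated 900 nM between 400 nM and 2000 nM.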

Compound 4, half-maximal effective concentration: 141 nM
Beside the measured number, compound 4's estimate is 6.4-fold (0.81 log units) above it; measured number below the stated range.
By their numbers in this assay, from the lowest: compound 4; then compounds 3, 2 and 1 (each within the scatter of the next).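

Replacing the group on the carbonyl carbon with 4-chloro-2,5-difluorophenyl gives a 6.0-fold lower number from compound 3 to compound 4 (0.78 log units; beyond the scatter) and a 6.5-fold lower number from compound 2 to compound 4 (0.81 log units; beyond the scatter) and a 7.2-fold lower number from compound 1 to compound 4 (0.86 log units; beyond the scatter) in this assay. Among the compounds shown here, these are the first steps beyond the scatter, so this position is not as flat as the earlier compounds suggested. Nothing available explains the drop.

Several atoms differ at once, so the part of the new group that matters remains open. Also open, going by these compounds, is how a phenyl group carrying a single fluorine, a nitrile or a carboxylic acid would behave at this place.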